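The compounds below may be only part of what the source reports. "The series", "measured", "known", "first", "only" and "open" are said of these compounds alone.

In a toxicity assay on HepG2 2.2.15 cells (Homo sapiens) for cytotoxicity, read by CellTiter-Glo (a higher number here means that more compound is tolerated, a lower number that less compound is tolerated), compound 1 `O=C1CC(Oc2ncccn2)CN1c1cnn2c1CN(C(=O)Nc1cc(F)c(F)c(F)c1)C(C1CC1)C2` reports only a limit, > 200000 nM. Compound 3 `C[C@H]1Cn2ncc(N3CC(c4ccccc4)CC3=O)c2CN1S(=O)(=O)Nc1cc(F)c(F)c(F)c1` likewise reports only a limit, > 2000 nM. Within the data shown here, compound 2 `O=C(Nc1cc(F)c(F)c(F)c1)N1Cc2c(-c3ccc(F)cc3F)cnn2CC1C1CC1` gives 32100 nM, the only actual number among the three. Compound 4 `O=C1OC(c2ccccc2)CN1c1cnn2c1CN(C(=O)Nc1cc(F)c(F)c(F)c1)C(C1CC1)C2` has 2-oxo-5-phenyl-1,3-oxazolidin-3-yl in place of 2,4-difluorophenyl on an aromatic carbon. Among the measured compounds shown here, no measured pair isolates this change, so the forecast is uncertain. A modest step towards more compound tolerated in this assay is expected, resting on compound 1, which also has a non-aromatic ring at that place and whose limit is > 200000 nM. The expected step is a 2.2-fold higher number from compound 2 to compound 4 (0.34 log units; beyond the scatter). Compound 4 is estimated at 70000 nM, within an expected range of 20000 nM to 200000 nM.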

Compound 4, half-maximal cytotoxic concentration: 7410 nM
Compound 4: the middle estimate sits 9.4-fold (0.98 log units) above what was measured; measured number outside the range, below it.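

Putting 2-oxo-5-phenyl-1,3-oxazolidin-3-yl in place of 2,4-difluorophenyl on this aromatic carbon gives a 4.3-fold lower number from compound 2 to compound 4 (0.64 log units; beyond the scatter) in this assay and so means that less compound is tolerated. A non-aromatic ring at this place therefore does not by itself raise the number. Compound 1, which also has a non-aromatic ring there, reports only a limit: the limit of > 200000 nM in this assay, at which 1 of the 4 values shown sits. On these data alone, it remains open whether the five-membered non-aromatic ring or its phenyl sets the lower number in compound 4, and how a simple amine or a carboxylic acid at this place would read.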